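Moving a Trifluoromethyl Group on the Urea Aryl Ring

The source may hold more compounds than are shown below. What is called first, only, known or untested is meant among the compounds shown, and "the series" means these compounds.

Compound 1 `CCN(CC)CCn1cnnc1-c1cc(Oc2ccc(NC(=O)Nc3cccc(C(F)(F)F)c3)cc2F)ccn1` has a shared core that ends in an amide-type nitrogen bearing an aromatic ring. In a functional assay on NCI-H460 cells (Homo sapiens) for antiproliferative activity, read by MTT assay, with a stated time of 72 h (a lower number here means a stronger inhibitor, a higher number a weaker inhibitor), compound 1 gives 9870 nM. Compound 2 `CCN(CC)CCn1cnnc1-c1cc(Oc2ccc(NC(=O)Nc3ccccc3C(F)(F)F)cc2F)ccn1` is built from the same atoms joined differently: 2-(trifluoromethyl)phenyl in place of 3-(trifluoromethyl)phenyl on an amide-type nitrogen. In this assay compound 2 gives > 50000 nM, which is a limit of the assay and not a number, as shown by the limit of > 50000 nM in this assay, at which 1 of the 3 values shown sits. The step is therefore known only as a bound: an at least 5.0-fold higher number from compound 1 to compound 2 (0.70 log units; beyond the scatter).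

Compound 3 `CN(C)CCCn1cnnc1-c1cc(Oc2ccc(NC(=O)Nc3cccc(C(F)(F)F)c3)cc2F)ccn1` differs from compound 1 in the chain on the core: (dimethylamino)methyl in place of diethylamino on a saturated chain carbon, two bonds along the chain from an aromatic nitrogen. In this assay compound 3 gives 1790 nM, the lowest of the two numbers seen, and the step is a 5.5-fold lower number from compound 1 to compound 3 (0.74 log units; beyond the scatter).

Compound 4 `CN(C)CCCn1cnnc1-c1cc(Oc2ccc(NC(=O)Nc3ccccc3C(F)(F)F)cc2F)ccn1` stands to compound 3 as compound 2 stands to compound 1: 2-(trifluoromethyl)phenyl in place of 3-(trifluoromethyl)phenyl on an amide-type nitrogen. The place of the change reads the same in both pairs, word for word, so this is the same change, made on a core that differs only in the chain already described. Among the compounds with values here, for compound 4 a step of an 8.4-fold higher number from compound 3 to compound 4 (0.92 log units; beyond the scatter) in this assay is expected, resting on the one measured instance of this change, an at least 5.0-fold higher number from compound 1 to compound 2 (0.70 log units; beyond the scatter). Because the measured step of an at least 5.0-fold higher number from compound 1 to compound 2 (0.70 log units; beyond the scatter) is only a bound, the true size could be larger, and compound 4 may itself reach the limit. Compound 4 is estimated at 15000 nM, within a range from 6000 nM to 50000 nM.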

Compound 4, half-maximal inhibitory concentration: 10900 nM
Compound 4: middle estimate off by 1.4-fold (0.14 log units), on the high side; the measured number falls inside the stated range.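

In this assay, 2-(trifluoromethyl)phenyl in place of 3-(trifluoromethyl)phenyl gives a 6.1-fold higher number from compound 3 to compound 4 (0.78 log units; beyond the scatter), so the change points the same way on both cores, toward a higher number and thus a weaker inhibitor: the same change on two cores in this assay, an at least 5.0-fold higher number (0.70 log units; beyond the scatter) from compound 1 to compound 2 and a 6.1-fold higher number (0.78 log units; beyond the scatter) from compound 3 to compound 4; the limit leaves it open whether they differ
The change in the chain carries over in the same way, with an at least 4.5-fold lower number from compound 2 to compound 4 (0.66 log units; beyond the scatter), again toward a lower number: the same change on two cores in this assay, a 5.5-fold lower number (0.74 log units; beyond the scatter) from compound 1 to compound 3 and an at least 4.5-fold lower number (0.66 log units; beyond the scatter) from compound 2 to compound 4; the limit leaves it open whether they differ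
Compound 2 gives > 50000 nM, which is a limit of the assay and not a number, so these pairs show a shared direction on two cores but do not show that either change has the same size on both.

The four compounds cover only two chains and two placements of one group on the aromatic ring, so they support no rule beyond themselves. As far as these compounds go, it remains open whether the same steps would appear with a morpholine in place of the diethylamino group, with a longer chain carrying the amine, or with a nitrile in place of the trifluoromethyl group.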